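A few compounds are considered here, and "the series" means these few. Any claim that something is new, unique, unknown or untested is made for them only; others in the source may bear on it.

Measured so far:
- compound 1, `CN(C(=O)NC(=O)c1ccccc1F)c1nc(C(F)(F)F)c(C(=O)N/N=C/c2ccc(C(F)(F)F)cc2)s1`: 3.87 ug/mL
- compound 2, `CN(C(=O)NC(=O)c1ccc([N+](=O)[O-])cc1)c1nc(C(F)(F)F)c(C(=O)N/N=C/c2cccc(C(F)(F)F)c2)s1`: 1.67 ug/mL
- compound 3, `CN(C(=O)NC(=O)c1ccc([N+](=O)[O-])cc1)c1nc(C(F)(F)F)c(C(=O)N/N=C/c2ccc([N+](=O)[O-])cc2)s1`: 7.45 ug/mL

All three were tested in a functional assay on BCG823 cells (Homo sapiens) for inhibition, read by MTT assay, with a stated time of 72 h; a higher number here means a weaker inhibitor, a lower number a stronger inhibitor. Compound 2 has the lowest number of the three: compound 1 sits nearest to it, and compound 3 sits furthest, reached by a 4.5-fold higher number from compound 2 to compound 3 (0.65 log units; beyond the scatter), a change of the group on a carbon with a double bond to nitrogen.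

The next compound, compound 4, `CN(C(=O)NC(=O)c1ccccc1F)c1nc(C(F)(F)F)c(C(=O)N/N=C/c2cccc(C(F)(F)F)c2)s1`, is not yet measured. Compared with compound 2 it carries a different group on the carbonyl carbon: 2-fluorophenyl in place of 4-nitrophenyl on a carbonyl carbon

No measured step changes this carbonyl group on its own, so nothing shown bears directly on it. The only step shown, from compound 2 to compound 3, concerns the other aryl group, and it was modest. Among the compounds with values here, compound 1 is the only compound that already carries a 2-fluorophenyl on the carbonyl carbon, but it also differs from compound 4 on the carbon with a double bond to nitrogen, so its value cannot be read as this step. With so little to go on, a small step is expected, most likely a slightly higher number: compound 4 is estimated at 2.6 ug/mL, within 1.2 ug/mL to 6 ug/mL, which would mean a 1.6-fold higher number from compound 2 to compound 4 (0.19 log units; within the scatter).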

Compound 4, half-maximal inhibitory concentration: 16.3 ug/mL
Beside the measured number, compound 4's estimate is 6.3-fold (0.80 log units) below it; the measured number lies above the stated range.
By their numbers in this assay, from the lowest: compound 2; then compounds 1 and 3 (each within the scatter of the next); then compound 4.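

In this assay, within the data shown here, the group on the carbonyl carbon turns out to matter a great deal: putting 2-fluorophenyl in place of 4-nitrophenyl gives a 9.8-fold higher number from compound 2 to compound 4 (0.99 log units; beyond the scatter), a change the earlier compounds could not show. The aryl group on the carbon with a double bond to nitrogen also counts, and not only through its kind: with 2-fluorophenyl on the carbonyl carbon, 3-(trifluoromethyl)phenyl in place of 4-(trifluoromethyl)phenyl gives a 4.2-fold higher number from compound 1 to compound 4 (0.62 log units; beyond the scatter), so 3-(trifluoromethyl)phenyl does not by itself secure a low number. No separate measurement is available to explain either step.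

Still open, going by these compounds, is whether a 4-fluorophenyl or a 2-nitrophenyl group on the carbonyl carbon would fall nearer to compound 2 or to compound 4, which would begin to separate the effect of the substituent itself from the effect of its place on the ring. Also open, on these data alone, is how a plain phenyl or a 4-aminophenyl group would behave there, and whether the difference between the two trifluoromethyl-bearing groups persists with 4-nitrophenyl on the carbonyl carbon.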